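The compounds below may be only part of what the source reports. "The series", "measured", "known", "first", "only" and "open" are said of these compounds alone.

Measured in a functional assay on SK-OV-3 cells (Homo sapiens) for inhibition, read by CCK-8 assay, with a stated time of 70 h; on this read-out higher numbers stand for weaker inhibition and lower numbers for stronger inhibition:
- Compound 1 `Clc1ccc(COc2ccc(OCCOCCNC3CCCC3)cc2)cc1`: 7670 nM
- Compound 2 `O=Cc1ccc(COc2ccc(OCCOCCNC3CCCC3)cc2)cc1`: 45000 nM
- Compound 3 `O=[N+]([O-])c1cccc(COc2ccc(OCCOCCNC3CCCC3)cc2)c1`: 15400 nM

Compound 3 stands at 15400 nM, with a 2.0-fold higher number from compound 1 to compound 3 (0.30 log units; within the scatter) on one side and a 2.9-fold lower number from compound 2 to compound 3 (0.47 log units; beyond the scatter) on the other. Compound 4 `O=[N+]([O-])c1ccccc1COc1ccc(OCCOCCNC2CCCC2)cc1` has the same atoms joined differently: 2-nitrophenyl in place of 3-nitrophenyl on a saturated chain carbon bound to an oxygen on an aromatic ring. In words, 2-nitrophenyl takes the place of 3-nitrophenyl on a saturated chain carbon bound to an oxygen on an aromatic ring.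

Among the measured compounds shown here, no measured step isolates a change of this kind. The nearest evidence comes from the steps that alter the same aromatic group, and those are a 2.0-fold higher number from compound 1 to compound 3 (0.30 log units; within the scatter) and a 2.9-fold lower number from compound 2 to compound 3 (0.47 log units; beyond the scatter). The largest step in the series is a 5.9-fold higher number from compound 1 to compound 2 (0.77 log units; beyond the scatter), and it exchanges one group for a different one, whereas the change here keeps the same group. A small shift is therefore expected in this assay, with no direction favoured by the data. The expected step is a 1.0-fold higher number from compound 3 to compound 4 (0.02 log units; within the scatter), which would not go beyond the scatter. Compound 4 is estimated at 16000 nM, with an expected range from 6000 nM to 40000 nM.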

Compound 4, half-maximal inhibitory concentration: 5370 nM
For compound 4 the middle estimate is 3.0-fold (0.47 log units) above the measured one; the measured number lies below the stated range.
By their numbers in this assay, from the lowest: compounds 4, 1 and 3 (each within the scatter of the next, the first and the last beyond it); then compound 2.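

In this assay, the nitro group's place on the ring proves to matter: with the same atoms joined differently, 2-nitrophenyl in place of 3-nitrophenyl gives a 2.9-fold lower number from compound 3 to compound 4 (0.46 log units; beyond the scatter), a step beyond the scatter. This separates two compounds that share the same substituent, while the change from 4-formylphenyl to 2-nitrophenyl gives an 8.4-fold lower number from compound 2 to compound 4 (0.92 log units; beyond the scatter), the largest step in the series. The change from 4-chlorophenyl to 2-nitrophenyl gives a 1.4-fold lower number from compound 1 to compound 4 (0.15 log units; within the scatter), so compound 4 cannot be ranked against compound 1, and no measurement is at hand to explain why the arrangement of the nitro group matters.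

As far as these compounds go, only the nitro group appears here in more than one arrangement, so it remains open whether chloro or formyl would respond in the same way. From the compounds shown here alone, it is also open how an amine or a carboxylic acid would behave on this ring, or whether a longer chain between the two ether oxygens would change the picture.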